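A few compounds are considered here, and "the series" means these few. Any claim that something is new, unique, unknown or untested is made for them only; others in the source may bear on it.

The series is followed in an ADME assay on Vero cells (Chlorocebus sabaeus) for cytotoxicity; a higher number here means that more compound is needed for the effect, a lower number that less compound is needed. Compound 1, `Cc1cc(N(C)C)nc(NCc2ccccc2)n1`, gives only a limit of the assay in this assay, > 50100 nM. Compound 2, `Cc1cc(N(C)C)nc(N[C@H]2CC[C@H](NC(=O)c3ccccc3)CC2)n1`, likewise gives only a limit, > 50100 nM. Within the data shown here, compound 3, `COc1cc(Nc2nc(C)cc(N3CCCCC3)n2)ccc1F`, is the one member for which this assay returns a number: compound 3 gives 15800 nM. Among the measured compounds shown here, compound 3 therefore stands alone as the only measured number of the three, the other two results being limits, and this is what the limit of > 50100 nM in this assay, at which 2 of the 3 values shown sit, records. Compound 3 differs from compound 1 and from compound 2 in more than one place. For the measured compounds named here, no single step can be drawn between them, and their values say only that two are limits and one is a number.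

Compound 4, `COc1cc(Nc2nc(C)cc(N3CCCC(C#N)C3)n2)ccc1F`, is reached from compound 3 by cyano in place of hydrogen on a saturated ring carbon, so that piperidin-1-yl becomes 3-cyanopiperidin-1-yl. Going by the values given here, no step between measured compounds resembles this change, so there is nothing to anchor it. It is estimated that the step of a 1.3-fold higher number from compound 3 to compound 4 (0.10 log units; within the scatter) stays within the scatter of this assay, with no direction favoured. For compound 4 the expected value in this assay is 20000 nM, between 8000 nM and 50100 nM.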

Compound 4, half-maximal effective concentration: 39800 nM
Compound 4: the middle estimate sits 2.0-fold (0.30 log units) below what was measured; the measured number falls inside the stated range.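

With compound 4 the series gains its first step that can be read, and it shows that this saturated ring carbon, two ring bonds from the ring nitrogen, is not silent in this assay: cyano in place of hydrogen gives a 2.5-fold higher number from compound 3 to compound 4 (0.40 log units; beyond the scatter), and the change of piperidin-1-yl to 3-cyanopiperidin-1-yl therefore lies beyond the scatter, though only modestly. Compound 4 still returns a number rather than a limit, so both ends of this step are numbers. Among these compounds, compound 1 and compound 2 remain limits and offer no step to set beside this one: the limit of > 50100 nM in this assay, at which 2 of the 4 values shown sit.

On these data alone, it stays open whether this step belongs to the cyano group itself or would also appear with another group at this carbon, such as a hydroxyl, a primary amine, a carboxylic acid or a longer chain ending in a nitrile. One step also cannot tell whether a change of this size would carry over to compounds with other groups on the shared core, such as compound 1 or compound 2.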